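Vinylcarbonyl to (Vinylcarbonyl)oxy: What to Expect

The source may hold more compounds than are shown below. What is called first, only, known or untested is meant among the compounds shown, and "the series" means these compounds.

In an in vitro assay on BL21-DE3 cells for displacement of a labelled ligand from thyroid hormone receptor beta (Homo sapiens), read by fluorescence polarization (a higher number here means a weaker inhibitor, a lower number a stronger inhibitor), compound 2 `C=CC(=O)c1ccc(CCCCC)cc1` gives 33900 nM, the second highest of the three numbers measured. Compound 1 `C=CC(=O)c1ccc(CCC)cc1` gives 100000 nM and compound 3 `C=CC(=O)c1ccc(CCCCCCCC)cc1` gives 11400 nM. The two measured steps that lead to or from compound 2, a 2.9-fold lower number from compound 1 to compound 2 (0.47 log units; beyond the scatter) and a 3.0-fold lower number from compound 2 to compound 3 (0.47 log units; beyond the scatter), both lengthen the chain on the shared core, and neither touches the vinylcarbonyl group. Compound 4 `C=CC(=O)Oc1ccc(CCCCC)cc1` differs from compound 2 by (vinylcarbonyl)oxy in place of vinylcarbonyl on an aromatic carbon. Among the measured compounds shown here, no measured step bears on this change, so the data give no direction for it. Compound 4 is therefore expected to sit near the number of its parent, a step of a 1.2-fold higher number from compound 2 to compound 4 (0.07 log units; within the scatter) with wide uncertainty. Compound 4 is estimated at 40000 nM, with a range from 10000 nM to 150000 nM.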

Compound 4, half-maximal inhibitory concentration: 55800 nM
Compound 4: the middle estimate sits 1.4-fold (0.14 log units) below what was measured; low and high end bracket the measured number.
By their numbers in this assay, from the lowest: compound 3; then compounds 2, 4 and 1 (each within the scatter of the next, the first and the last beyond it).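

In this assay, swapping vinylcarbonyl for (vinylcarbonyl)oxy on an aromatic carbon para to a pentyl group gives a 1.6-fold higher number from compound 2 to compound 4 (0.22 log units; within the scatter), so this change stays within the usual scatter of repeated measurements. Among the compounds shown here, it is the first reading at this position, since the earlier steps changed only the chain. No measurement shown here accounts for this result. On these data alone, whether the swap reads the same on the chains of compound 1 and compound 3 remains open. So does the reading for an amide, with nitrogen in place of the added oxygen.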